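Chloro in Place of Methoxy on the Benzyl Group

A few compounds are considered here, and "the series" means these few. Any claim that something is new, unique, unknown or untested is made for them only; others in the source may bear on it.

Compound 1: `COc1ccc(CN2C(=O)/C(=C\c3cc(OC)c(OC)c(OC)c3)c3ccccc32)cc1` — 21400 nM
Compound 2: `COc1cc(/C=C2\C(=O)N(C)c3ccc(Cl)cc32)cc(OC)c1OC` — 36300 nM

Both numbers come from a functional assay on cells (Cancer cell lines, Homo sapiens) for cytotoxicity, with a stated time of 48 h; on this read-out higher numbers stand for weaker inhibition of growth and lower numbers for stronger inhibition of growth. Compound 1 has the lowest of the two numbers, but compound 2 sits only within the scatter of it, so the two cannot be told apart, and no single change connects their structures. The unmeasured compound 3 is `COc1cc(/C=C2\C(=O)N(Cc3ccc(Cl)cc3)c3ccccc32)cc(OC)c1OC`. It keeps the whole frame of compound 1 and differs in one place: chloro in place of methoxy on an aromatic carbon. Going by the values given here, nothing among the measured compounds shows how this exchange acts on its own, and compound 2 cannot serve as a guide because it carries other changes as well. Without such a guide, the step is expected to be small, with no direction beyond the scatter: from compound 1 to compound 3 the estimate is a 1.1-fold lower number from compound 1 to compound 3 (0.03 log units; within the scatter). Compound 3 is therefore expected to give about 20000 nM in this assay, within a range from 7000 nM to 60000 nM.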

Compound 3, concentration for total growth inhibition: 22900 nM
The estimate for compound 3 lay 1.1-fold (0.06 log units) below the measured number, within the range that was stated.
By their numbers in this assay, from the lowest: compounds 1, 3 and 2 (each within the scatter of the next).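

Exchanging 4-methoxybenzyl for 4-chlorobenzyl on the shared core gives a 1.1-fold higher number from compound 1 to compound 3 (0.03 log units; within the scatter) in this assay, which is a direct reading of this change on its own. At this place, para to a large group, methoxy and chloro cannot be told apart on this read-out, although the two groups differ in their atoms and only methoxy counts a hydrogen-bond acceptor. No other measurement accompanies this result that could explain it. Only this one exchange at this one place is shown, so it stays open whether an amine or a carboxylic acid there would also leave the number within the scatter of compound 1. Going by these compounds, it also stays open whether chloro in place of methoxy would read the same elsewhere on the core of compound 1.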